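A bromine swap among compounds at the assay limit

The compounds below may be only part of what the source reports. "The series", "measured", "known", "first", "only" and "open" are said of these compounds alone.

Measured in a functional assay on HepG2 cells (Homo sapiens) for cytotoxicity, with a stated time of 72 h (a higher number here means that more compound is needed for the effect, a lower number that less compound is needed), for three compounds
Compound 1 `C=C[C@@](C)(/C=C/c1ccc(OCc2ccccc2)cc1)CCC=C(C)C` gives > 52000 nM as a limit
Compound 2 `C=C[C@@](C)(/C=C/c1ccc(Nc2ccccc2)cc1)CCC=C(C)C` gives > 52000 nM as a limit
Compound 3 `C=C[C@@](C)(/C=C/c1ccc(-c2ccc(F)cc2)cc1)CCC=C(C)C` gives > 52000 nM as a limit

All three results are limits, with the limit of > 52000 nM in this assay, at which 3 of the 3 values shown sit, as the shared evidence. Compound 3 stands at its limit of > 52000 nM and so has no number. Compound 4 `C=C[C@@](C)(/C=C/c1ccc(-c2cccc(Br)c2)cc1)CCC=C(C)C` differs in one place, on an aromatic carbon para to a large group, where 3-bromophenyl replaces 4-fluorophenyl as 3-bromophenyl in place of 4-fluorophenyl on an aromatic carbon counts. The steps at this same place are a step that the two limits leave unreadable from compound 1 to compound 3 and a step that the two limits leave unreadable from compound 2 to compound 3 and neither has a size. No step beyond the scatter is therefore expected in this assay and another limit is the likeliest report. The expected change is a step that the limit leaves unreadable from compound 3 to compound 4 in this estimate. Compound 4 is expected near 55000 nM with an estimated range from 28000 nM to 110000 nM if a number is reported at all.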

Compound 4, half-maximal effective concentration: > 52000 nM
Compound 4: no number, only a limit; the forecaster's own chance of this, stated with the estimate: 85%; the middle value lies beyond the limit too.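

In this assay compound 4 gives > 52000 nM, which is a limit and not a number. Its steps to compound 1, compound 2 and compound 3 cannot be read. The compounds shown leave open whether any of these groups changes the result, and how far apart the four compounds truly lie.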